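Three Amides at the Assay Limit, a Fourth Untested

A few compounds are considered here, and "the series" means these few. Any claim that something is new, unique, unknown or untested is made for them only; others in the source may bear on it.

Compound 1 `CCCNC(=O)c1cc(-n2cc(-c3cc(F)cc(F)c3)nn2)ccc1O` was examined in a functional assay on RAW264.7 cells (Mus musculus) for inhibition, read by Griess assay, with a stated time of 20 h; a lower number here means a stronger inhibitor, a higher number a weaker inhibitor. In this assay compound 1 gives > 20000 nM, which is a limit of the assay and not a number. Compound 3 `O=C(c1cc(-n2cc(-c3cc(F)cc(F)c3)nn2)ccc1O)N1CCCCC1` differs from compound 1 by piperidin-1-yl in place of propylamino on a carbonyl carbon. In this assay compound 3 gives > 20000 nM, again only a limit. The step that the two limits leave unreadable from compound 1 to compound 3 therefore cannot be read. Compound 2 `CCCNC(=O)c1cc(-n2cc(-c3cc(C(F)(F)F)cc(C(F)(F)F)c3)nn2)ccc1O` carries the same propylcarbamoyl as compound 1; the difference between the two cores is not broken down here. In this assay compound 2 gives > 20000 nM, also a limit. Compound 4 `O=C(c1cc(-n2cc(-c3cc(C(F)(F)F)cc(C(F)(F)F)c3)nn2)ccc1O)N1CCCCC1` differs from compound 2 by piperidin-1-yl in place of propylamino on a carbonyl carbon, the same change as that from compound 1 to compound 3. Given (the limit of > 20000 nM in this assay, at which 3 of the 3 values shown sit), the step that the limit leaves unreadable from compound 2 to compound 4 is expected to remain unreadable. Compound 4 is estimated at 40000 nM, most probably reported once more only as a limit.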

Compound 4, half-maximal inhibitory concentration: 12800 nM
Compound 4: middle estimate off by 3.1-fold (0.49 log units), on the high side, outside the stated range (below it).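

In this assay the change from propylamino to piperidin-1-yl on a carbonyl carbon gives an at least 1.5-fold lower number from compound 2 to compound 4 (0.19 log units; that floor lies within the scatter), and the floor of that step does not by itself clear the scatter. Compound 2 gives > 20000 nM, which is a limit of the assay and not a number. The same change on the core of compound 1 cannot be read, so the data show neither that the step carries from one core to the other nor that it fails to: the limit of > 20000 nM in this assay, at which 3 of the 4 values shown sit.

Going by these compounds, how large the step from propylamino to piperidin-1-yl really is remains open. So does whether morpholin-4-yl or a longer chain such as butylamino, on the same carbonyl carbon, would give a measurable number on either core.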